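This account rests on a few compounds, and the source may have more. Where it says the series, first, only, none or still open, it means among the compounds named here.

Compound 3 `O=c1oc2c(O)c(O)ccc2cc1-c1cccs1` was tested in a functional assay on isolated protein for antagonist activity at adenosine receptor A2b (Homo sapiens); on this read-out higher numbers stand for weaker inhibition and lower numbers for stronger inhibition. In this assay compound 3 gives only a limit, > 30000 nM. Compound 2 `O=c1oc2c(O)cccc2cc1-c1cccs1` likewise gives only a limit in this assay, > 30000 nM. The step that the two limits leave unreadable from compound 2 to compound 3 therefore cannot be read, because both sit at the limit of > 30000 nM in this assay, at which 3 of the 3 values shown sit. Compound 1 `CC(=O)Oc1ccc2cc(-c3ccsc3)c(=O)oc2c1OC(C)=O`, which already carries the thiophen-3-yl group, also gives only a limit in this assay, > 30000 nM. Compound 4 `O=c1oc2c(O)c(O)ccc2cc1-c1ccsc1` differs from compound 3 by thiophen-3-yl in place of thiophen-2-yl on an aromatic carbon. Going by the values given here, no measured step bears on this change, so no shift beyond the scatter is expected, and the most likely outcome is again a limit. Compound 4 is estimated at 60000 nM with a range from 20000 nM to 300000 nM. This estimate means a step that the limit leaves unreadable from compound 3 to compound 4 that is expected to stay within the scatter.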

Compound 4, inhibition constant: > 30000 nM
Compound 4 ended at the assay's limit (the forecaster's own chance of this, stated with the estimate: 85%); the middle value lies beyond the limit too.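

Compound 3 and compound 4 both give only limits in this assay, so the change from thiophen-2-yl to thiophen-3-yl cannot be read as a step: the limit of > 30000 nM in this assay, at which 4 of the 4 values shown sit.

On these data alone, whether that change alters inhibition at all remains open.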